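This account rests on a few compounds, and the source may have more. Where it says the series, first, only, none or still open, it means among the compounds named here.

Working notes on the series.

Compound 1 `CCc1ccccc1NS(=O)(=O)c1ccc(NC(=O)NCCCCl)cc1` sets the starting point in a functional assay on HT-29 cells (Homo sapiens) for cytotoxicity, read by sulforhodamine B assay, with a stated time of 48 h; a lower number here means a stronger inhibitor, a higher number a weaker inhibitor. For compound 1 the value recorded is only a limit of the assay, > 200000 nM. Compound 2 `CCCc1ccccc1NS(=O)(=O)c1ccc(NC(=O)NCCCCl)cc1` differs from compound 1 by the change (methyl in place of hydrogen on a saturated chain carbon, two bonds along the chain from an aromatic carbon), and in this assay compound 2 gives 26000 nM. The step of an at least 7.6-fold lower number from compound 1 to compound 2 (0.88 log units; beyond the scatter) can be given only as a floor, because the limit of > 200000 nM in this assay, at which 1 of the 3 values shown sits, defines one end of it; the true size of the step is not pinned down.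

Compound 3 `CCNC(=O)Nc1cccc(S(=O)(=O)Oc2ccccc2CC)c1` carries a different core; how the core of compound 3 differs from the core of compound 1 is not broken down here. In this assay compound 3 gives 33000 nM, which sits close to the number for compound 2, within the usual scatter.

Compound 4 `CCCc1ccccc1OS(=O)(=O)c1cccc(NC(=O)NCC)c1` has not yet been measured in this assay. Within the data shown here, compound 4 differs from compound 3 by methyl in place of hydrogen on a saturated chain carbon, two bonds along the chain from an aromatic carbon, the same change as the one from compound 1 to compound 2, made at the same place. The expectation for compound 4 therefore rests on that earlier step, an at least 7.6-fold lower number from compound 1 to compound 2 (0.88 log units; beyond the scatter), read as a floor. It rests also on the number for compound 3, 33000 nM. For compound 4 a step of a 3.3-fold lower number from compound 3 to compound 4 (0.52 log units; beyond the scatter) is expected, in the same direction as the earlier one, though taken more cautiously since the earlier step is a floor and a single instance. Compound 4 is estimated at 10000 nM in this assay, with a range from 3000 nM to 30000 nM.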

Compound 4, half-maximal inhibitory concentration: 25000 nM
Compound 4: the middle estimate sits 2.5-fold (0.40 log units) below what was measured, and the stated range covers the measured number.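

On the core of compound 3, the change from ethyl to propyl gives a 1.3-fold lower number from compound 3 to compound 4 (0.12 log units; within the scatter), so in this assay the step seen on the core of compound 1 does not carry over at the same size: the same change on two cores in this assay, an at least 7.6-fold lower number (0.88 log units; beyond the scatter) from compound 1 to compound 2 and a 1.3-fold lower number (0.12 log units; within the scatter) from compound 3 to compound 4, at least 5.8-fold (0.76 log units) apart, beyond the scatter of two such steps

The true size of the earlier step, and so of the gap between the two steps, stays unknown, as one end of it is a limit of the assay and not a number: the limit of > 200000 nM in this assay, at which 1 of the 4 values shown sits.

Among these compounds, with a single pair on each core, these results show only that the same change can give different steps on these two cores; they do not show which difference between the cores goes with the different steps, and they give no general rule for the series.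

Left open is how a longer chain such as butyl, or a chain carrying an amine or a carboxylic acid, would read in this assay on either core. Also open, on these data alone, is whether a third core would follow the step seen on the core of compound 1 or the one seen on the core of compound 3.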